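The source may report more compounds than this note shows. Statements on the series, on what has been measured and on what is new or still open speak of the compounds shown alone.

Compound 2 `CCN1CCN(CCCn2cnc3c(N4CCN(CC)CC4)nc(NCc4ccc(N(CC)CC)cc4)nc32)CC1` is a central point in this small set. In an assay on HEK293 cells for antagonist activity at Toll-like receptor 9 (Homo sapiens), read by spectrophotometry (on this read-out lower numbers stand for stronger inhibition and higher numbers for weaker inhibition), compound 2 gives 440 nM. Compound 3 `CCN1CCN(CCCn2cnc3c(N4CCN(CC)CC4)nc(NC(=O)c4ccccc4)nc32)CC1` gives 340 nM in this assay, and the two lie within the scatter of each other, as a 1.3-fold lower number from compound 2 to compound 3 (0.11 log units; within the scatter) shows. Going by the values given here, compound 1 `CCN1CCN(CCCn2cnc3c(N4CCN(C(=O)C5CCCC5)CC4)nc(NCc4ccc(N(CC)CC)cc4)nc32)CC1`, with its cyclopentylcarbonyl group, gives 8800 nM in this assay, far from compound 2; the step of a 20-fold lower number from compound 1 to compound 2 (1.30 log units; beyond the scatter) is the one large change seen.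

Compound 4 `CCN1CCN(CCCn2cnc3c(N4CCN(C5CCCC5)CC4)nc(NCc4ccc(N(CC)CC)cc4)nc32)CC1` differs from compound 2 in one place: cyclopentyl in place of ethyl on an amine nitrogen in a ring. Among the compounds with values here, only the step from compound 1 to compound 2 bears on this change, and only in part: it removed a cyclopentyl ring together with a carbonyl, whereas compound 4 brings back the five-membered carbon ring directly on the ring nitrogen with no carbonyl. Since that removal lowered the number greatly, as a 20-fold lower number from compound 1 to compound 2 (1.30 log units; beyond the scatter) records, a rise in the number is expected for compound 4 in this assay, but a smaller one, estimated as a 2.3-fold higher number from compound 2 to compound 4 (0.36 log units; beyond the scatter). Compound 4 is therefore estimated at 1000 nM in this assay, within a range of 300 nM to 4000 nM.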

Compound 4, half-maximal inhibitory concentration: 150 nM
The estimate for compound 4 lay 6.7-fold (0.82 log units) above the measured number; the measured number lies below the stated range.
By their numbers in this assay, from the lowest: compound 4; then compounds 3 and 2 (each within the scatter of the next); then compound 1.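

In this assay, replacing ethyl with the five-membered carbon ring on this amine nitrogen gives a 2.9-fold lower number from compound 2 to compound 4 (0.47 log units; beyond the scatter) and so is tolerated, even favoured, at this position. With the cyclopentyl ring kept and only the carbonyl gone, the change gives a 59-fold lower number from compound 1 to compound 4 (1.77 log units; beyond the scatter) and separates what compound 1 alone could not: its high number goes with the carbonyl link and not with the cyclopentyl ring. Nothing shown here accounts for either step.

The compounds shown leave open whether a cyclopropyl or cyclohexyl ring, an isopropyl group or a piperidin-4-yl ring on the same nitrogen would follow cyclopentyl. They also leave open whether cyclopentyl would lower the number in the same way with the benzoyl group of compound 3 in place of the 4-(diethylamino)benzyl group.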